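Dropping the methoxy from compound 3

The source may hold more compounds than are shown below. What is called first, only, known or untested is meant among the compounds shown, and "the series" means these compounds.

In a functional assay on QG-56 cells (Homo sapiens) for antiproliferative activity (a higher number here means a weaker inhibitor, a lower number a stronger inhibitor), compound 3 `COc1ccc(-c2cc([N+](=O)[O-])cc3cc(C(O)(c4ccc(C#N)cc4)c4cncn4C)oc23)cc1` gives 36 nM as the lowest of three numbers. Compound 4 `Cn1cncc1C(O)(c1ccc(C#N)cc1)c1cc2cc([N+](=O)[O-])cc(-c3ccccc3)c2o1` is still unmeasured and departs from compound 3 by hydrogen in place of methoxy on an aromatic carbon with hydrogen in place of methoxy on an aromatic carbon. Within the data shown here, no measured step covers this change. Among the measured compounds shown here, the only step, a 3.5-fold higher number from compound 1 to compound 2 (0.54 log units; beyond the scatter) with chloro in place of nitro, concerns another group. Still, compound 1 `Cn1cncc1C(O)(c1ccc([N+](=O)[O-])cc1)c1cc2cc([N+](=O)[O-])cc(-c3ccccc3)c2o1` at 547 nM and compound 2 `Cn1cncc1C(O)(c1ccc(Cl)cc1)c1cc2cc([N+](=O)[O-])cc(-c3ccccc3)c2o1` at 1890 nM carry the phenyl of compound 4 yet lack its nitrile. Both stand above compound 3, so a moderate rise beyond the scatter is expected in this assay with uncertain size. The expected change is a 4.2-fold higher number from compound 3 to compound 4 (0.62 log units; beyond the scatter) in this estimate. Compound 4 is estimated at 150 nM with a range from 40 nM to 600 nM as its likely span.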

Compound 4, half-maximal inhibitory concentration: 1480 nM
Compound 4: the middle estimate sits 9.9-fold (0.99 log units) below what was measured, and the stated range ends below it.
By their numbers in this assay, from the lowest: compound 3; then compound 1; then compounds 4 and 2 (each within the scatter of the next).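

In this assay, the 4-methoxyphenyl to phenyl change gives a large step (a 41-fold higher number from compound 3 to compound 4 (1.61 log units; beyond the scatter)), the first sign that this position strongly affects the number. With phenyl in place, nitrile and chloro cannot be told apart (a 1.3-fold lower number from compound 2 to compound 4 (0.11 log units; within the scatter)), while nitrile in place of nitro gives a modest step (a 2.7-fold higher number from compound 1 to compound 4 (0.43 log units; beyond the scatter)). The low number of compound 3 therefore does not come from the nitrile alone; the methoxy is also needed in this series.

On these data alone, whether a hydroxy, an amine or an ethoxy in that place would keep the number low remains open. Nothing given here explains the size of the methoxy step.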